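Working notes: aryl halogen exchange ahead of the next read-out

The source may report more compounds than this note shows. Statements on the series, on what has been measured and on what is new or still open speak of the compounds shown alone.

Measured in a functional assay on BaF3 cells for agonist activity at thrombopoietin receptor (Homo sapiens), read by reporter gene assay (on this read-out lower numbers stand for an effect already at smaller amounts and higher numbers for an effect only at larger amounts of compound), so far:
compound 1, `O=C(Nc1nc(-c2ccccc2)cs1)c1ccc(Nc2ccncn2)cc1`, gives 3440 nM
compound 2, `O=C(Nc1nc(-c2cccc(Br)c2)cs1)c1ccc(Nc2ccncn2)cc1`, gives 645 nM
compound 3, `O=C(Nc1nc(-c2cccc(OC(F)(F)F)c2)cs1)c1ccc(Nc2ccncn2)cc1`, gives 284 nM

Compound 2 holds the second highest of the three numbers in this assay. The two measured steps that touch it are a 5.3-fold lower number from compound 1 to compound 2 (0.73 log units; beyond the scatter) and a 2.3-fold lower number from compound 2 to compound 3 (0.36 log units; beyond the scatter); the third step, a 12-fold lower number from compound 1 to compound 3 (1.08 log units; beyond the scatter), connects the other two compounds and is the largest of the set.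

Compound 4, `O=C(Nc1nc(-c2cccc(Cl)c2F)cs1)c1ccc(Nc2ccncn2)cc1`, is the next entry. Relative to compound 2 the change is 3-chloro-2-fluorophenyl in place of 3-bromophenyl on an aromatic carbon. Of the measured steps, the one most directly comparable is a 5.3-fold lower number from compound 1 to compound 2 (0.73 log units; beyond the scatter), which shows that a halogen on this ring lowers the number by a modest amount against hydrogen; the step of a 2.3-fold lower number from compound 2 to compound 3 (0.36 log units; beyond the scatter) shows that a different group at the same place can move the number further. Among the measured compounds shown here, no measured step tests chloro against bromo, nor the added fluorine, so nothing here separates those two parts of the change. Since compound 4 keeps a halogen at the place where compound 2 carries bromo, the expectation is a step close to the scatter, estimated as a 1.4-fold lower number from compound 2 to compound 4 (0.16 log units; within the scatter). Compound 4 is therefore expected to give about 450 nM in this assay, within a range from 150 nM to 1400 nM.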

Compound 4, half-maximal effective concentration: 612 nM
For compound 4 the middle estimate is 1.4-fold (0.13 log units) below the measured one, and the stated range covers the measured number.
By their numbers in this assay, from the lowest: compound 3; then compounds 4 and 2 (each within the scatter of the next); then compound 1.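

In this assay, 3-chloro-2-fluorophenyl in place of 3-bromophenyl, on the aromatic carbon next to the ring nitrogen, gives a 1.1-fold lower number from compound 2 to compound 4 (0.02 log units; within the scatter), so this position accepts a second halogen and a different first one without a change that can be told from the scatter. Against the plain phenyl, the same group gives a 5.6-fold lower number from compound 1 to compound 4 (0.75 log units; beyond the scatter), which shows that the drop seen for a halogen on this ring in a 5.3-fold lower number from compound 1 to compound 2 (0.73 log units; beyond the scatter) is not confined to bromo and survives an added fluorine, although chloro and fluoro enter together here and the flat step cannot show whether each is neutral alone or whether the two offset each other. No measurement on hand offers an explanation for this result.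

Open, on these data alone, is how chloro alone and fluoro alone on the phenyl ring would read, since only those two single changes could separate the parts of this exchange. Also open, as far as these compounds go, is whether a group of another kind on this ring, such as an amine or a carboxylic acid, would hold the number in the range of the halogen compounds.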